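The source may report more compounds than this note shows. Statements on the series, on what has been measured and on what is new or still open speak of the compounds shown alone.

Measured compounds in an assay on CHO cells for displacement of a labelled ligand from adenosine receptor A1 (Homo sapiens), read by scintillation counting, tested at 10 uM; a higher number here means more inhibition at the concentration tested (going by the name of the read-out), a lower number less inhibition:
Compound 1 `CC(C)(C)Cc1c(/C=C/c2ccc(Cl)cc2)sc(N)c1C(=O)c1ccc(Cl)cc1` gives 1%.
Compound 2 `CC(C)(C)Cc1csc(N)c1C(=O)c1ccc(Cl)c(Cl)c1` gives 1%.
Compound 3 `CC(C)(C)Cc1c(Br)sc(N)c1C(=O)c1cccc(C(F)(F)F)c1` gives 1%.

All three share the same core and differ only in the groups hung on it. Compound 1 stands level with compound 2 and compound 3 at the digits given; the differences between them lie within the scatter of this assay, so none can be called stronger or weaker than another.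

Compound 4 `CC(C)(C)Cc1c(-c2ccsc2)sc(N)c1C(=O)c1ccc(Cl)cc1` has not yet been measured. It differs from compound 1 in one place: thiophen-3-yl in place of 2-(4-chlorophenyl)ethenyl on an aromatic carbon.

Among the compounds with values here, no measured pair shows a step of this kind, so the expectation rests on the three values alone, all of which sit at the bottom of the scale. Compound 4 is expected to stay there too, with the step of a number 2 percentage points higher from compound 1 to compound 4 (within the scatter) not going beyond the scatter. The estimate for compound 4 is 3%, in the range 0% to 15%.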

Compound 4, a percentage reported as inhibition, at one concentration (the size of the read-out at that concentration, not a potency): 2%
Beside the measured number, compound 4's estimate is 1 percentage points above it; low and high end bracket the measured number.
By their numbers in this assay, from the lowest: compounds 1, 2, 3 and 4 (each within the scatter of the next).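

In this assay, putting thiophen-3-yl at the aromatic carbon next to the ring sulfur in place of 2-(4-chlorophenyl)ethenyl gives a number 1 percentage points higher from compound 1 to compound 4 (within the scatter). This position therefore takes either a five-membered aromatic ring with one sulfur or a larger group with a six-membered aromatic ring and a double bond, and the read-out stays at the bottom of the scale with both. From the compounds shown here alone, whether an amine or a carboxylic acid on this carbon would raise the read-out remains open. No further measurement bears on this result.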